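A Methyl on the Piperidine Ring of Compound 2

The source may hold more compounds than are shown below. What is called first, only, known or untested is meant among the compounds shown, and "the series" means these compounds.

Three compounds built on one shared core differ only in the aryl group on an aromatic nitrogen. In a functional assay on A549 cells (Homo sapiens) for cytotoxicity, read by MTT assay, with a stated time of 72 h (a lower number here means a stronger inhibitor, a higher number a weaker inhibitor), compound 1 `COc1cc2c(Oc3ccc(NC(=O)c4cn(-c5ccccc5OC)cn4)cc3F)ccnc2cc1OCCCN1CCCCC1` gives 120 nM. Compound 2 `COc1cc2c(Oc3ccc(NC(=O)c4cn(-c5cc(C)ccc5C)cn4)cc3F)ccnc2cc1OCCCN1CCCCC1` gives 510 nM, and compound 3 `COc1cc2c(Oc3ccc(NC(=O)c4cn(-c5ccc(Cl)cc5Cl)cn4)cc3F)ccnc2cc1OCCCN1CCCCC1` gives 7490 nM. Among these three numbers compound 2 stands second highest: there is a 4.3-fold higher number from compound 1 to compound 2 (0.63 log units; beyond the scatter), and a 15-fold higher number from compound 2 to compound 3 (1.17 log units; beyond the scatter), while the longest span is a 62-fold higher number from compound 1 to compound 3 (1.80 log units; beyond the scatter).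

Compound 4 `COc1cc2c(Oc3ccc(NC(=O)c4cn(-c5cc(C)ccc5C)cn4)cc3F)ccnc2cc1OCCCN1CCC(C)CC1` keeps the 2,5-dimethylphenyl group of compound 2 and changes the other end of the molecule: methyl in place of hydrogen on a saturated ring carbon. None of the three measured steps touches this part of the structure; every one of them swaps the aryl group on the aromatic nitrogen and leaves the piperidin-1-yl ring unchanged. For the measured compounds named here, the data therefore give no direct guide for the step from compound 2 to compound 4, and with only one small group entering on a saturated ring carbon, the account expects no shift beyond the usual scatter in this assay.

The estimate for compound 4 in this assay is 510 nM, within a range from 200 nM to 1300 nM. This expected value corresponds to a step of no change at the digits printed from compound 2 to compound 4 (within the scatter).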

Compound 4, half-maximal inhibitory concentration: 7420 nM
Beside the measured number, compound 4's estimate is 15-fold (1.16 log units) below it; the measured number lies above the stated range.
By their numbers in this assay, from the lowest: compound 1; then compound 2; then compounds 4 and 3 (each within the scatter of the next).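

For the compounds shown here, the earlier compounds showed only that the aryl group on the aromatic nitrogen moves the number in this assay, as in a 15-fold higher number from compound 2 to compound 3 (1.17 log units; beyond the scatter). The new result shows that the other end of the molecule matters as well: methyl in place of hydrogen on a saturated ring carbon, three ring bonds from the ring nitrogen, brings a 15-fold higher number from compound 2 to compound 4 (1.16 log units; beyond the scatter), a step also classed as large although the change adds just 1 heavy atom. Nothing available here accounts for this step, so its cause stays unknown.

Going by these compounds, it remains open whether 4-methylpiperidin-1-yl would raise the number to a similar extent when paired with the 2-methoxyphenyl group of compound 1 or the 2,4-dichlorophenyl group of compound 3. Also open, on these data alone, is how this assay would respond to an ethyl group or a hydroxyl group on the same ring carbon, or to a morpholine ring in place of the piperidine ring.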